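The source may report more compounds than this note shows. Statements on the series, on what has been measured and on what is new or still open speak of the compounds shown alone.

Compound 2, `CCCCCCCCNc1cncc(C(=O)NCc2ccccc2)n1`, in an ADME assay on HEL cells (Homo sapiens) for cytotoxicity, read by microscopy, with a stated time of 6 days (a lower number here means that less compound is tolerated, a higher number that more compound is tolerated), gives > 100000 nM, which is a limit of the assay rather than a number. Compound 1, `CCCCCCNc1cncc(C(=O)NCc2ccccc2)n1`, in this assay likewise gives > 100000 nM, again a limit. The step between them, a step that the two limits leave unreadable from compound 1 to compound 2, therefore cannot be sized from the two values. Compound 3, `CCCCCCCNc1cncc(C(=O)NCc2ccccc2)n1`, is not yet measured; it differs from compound 2 by hydrogen in place of methyl on a saturated chain carbon, seven bonds along the chain from a nitrogen on an aromatic ring. Going by the values given here, only that one measured step bears on this change, and since it is unreadable, no size can be drawn from it. What the two measured values do show is the limit of > 100000 nM in this assay, at which 2 of the 2 values shown sit, and on that basis compound 3 is expected to sit there as well, so that a number no higher from compound 2 to compound 3 (the limit leaves the size open) is expected to be no larger than the scatter. The estimate for compound 3 in this assay is 100000 nM, between 50000 nM and 200000 nM, most likely reported once more as a limit.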

Compound 3, minimum cytotoxic concentration: > 100000 nM
Compound 3 ended at the assay's limit (the forecaster's own chance of this, stated with the estimate: 90%); the middle value lies on the limit itself.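

Compound 1, compound 2 and compound 3 all end at a limit of the assay rather than at a number, so no step among them can be read: the limit of > 100000 nM in this assay, at which 3 of the 3 values shown sit.

The compounds shown leave open whether these three differ at all in this assay, and what concentration of any of them would first harm the cells.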